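This account rests on a few compounds, and the source may have more. Where it says the series, first, only, none or still open, it means among the compounds named here.

Measured so far in a functional assay on MCF7 cells (Homo sapiens) for antiproliferative activity, with a stated time of 5 days; a lower number here means a stronger inhibitor, a higher number a weaker inhibitor:

Compound 1 `COc1ccc(-c2[nH]c3ccc(C(C)C)cc3c2C=O)cc1` gives 97 nM.
Compound 2 `COc1ccc(-c2[nH]c3ccc(C(C)(C)C)cc3c2C=O)cc1` gives 580 nM.
Compound 3 `CCCCCc1ccc2[nH]c(-c3ccc(OC)cc3)c(C=O)c2c1` gives 20 nM.

Compound 3 stands lowest of the three. Against compound 1 it differs by pentyl in place of isopropyl on an aromatic carbon, and the step is a 4.9-fold lower number from compound 1 to compound 3 (0.69 log units; beyond the scatter). Compound 2 differs from compound 1 by methyl in place of hydrogen on a saturated chain carbon bound to an aromatic carbon and two saturated chain carbons, and that step is a 6.0-fold higher number from compound 1 to compound 2 (0.78 log units; beyond the scatter); from compound 2 to compound 3 the step is a 29-fold lower number from compound 2 to compound 3 (1.46 log units; beyond the scatter).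

Compound 4 `CCCCCCc1ccc2[nH]c(-c3ccc(OC)cc3)c(C=O)c2c1` has not yet been measured. It differs from compound 3 by methyl in place of hydrogen on a saturated chain carbon, five bonds along the chain from an aromatic carbon. Among the measured compounds shown here, this is the same kind of change as the one from compound 1 to compound 2, yet not the same: there the added methyl sits on a saturated chain carbon bound to an aromatic carbon and two saturated chain carbons, here on a saturated chain carbon five bonds along the chain from an aromatic carbon. The cores of the two pairs also differ, as told by pentyl in place of isopropyl on an aromatic carbon. For the measured compounds named here, since the only measured example of this kind of change, a 6.0-fold higher number from compound 1 to compound 2 (0.78 log units; beyond the scatter), sits at a different place, and since going from isopropyl to pentyl gave a 4.9-fold lower number from compound 1 to compound 3 (0.69 log units; beyond the scatter), the step from compound 3 to compound 4 is expected to be small, about a 1.3-fold higher number from compound 3 to compound 4 (0.10 log units; within the scatter). Compound 4 is estimated at 25 nM, between 8 nM and 80 nM.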

Compound 4, half-maximal inhibitory concentration: 6 nM
Estimate against measurement, compound 4: 4.2-fold (0.62 log units) above, and the stated range ends above it.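

In this assay, methyl in place of hydrogen on the pentyl chain gives a 3.3-fold lower number from compound 3 to compound 4 (0.52 log units; beyond the scatter), while hexyl in place of the smaller branched groups gives a 97-fold lower number from compound 2 to compound 4 (1.99 log units; beyond the scatter) and a 16-fold lower number from compound 1 to compound 4 (1.21 log units; beyond the scatter). The same kind of change, methyl in place of hydrogen, moved the number in opposite directions on the two cores: the same change on two cores in this assay, a 6.0-fold higher number (0.78 log units; beyond the scatter) from compound 1 to compound 2 and a 3.3-fold lower number (0.52 log units; beyond the scatter) from compound 3 to compound 4, 20-fold (1.30 log units) apart, beyond the scatter of two such steps This shows that the step seen on one core cannot be carried to the other as a fixed amount, but it does not show whether the core or the place of the methyl decides the outcome, as the methyl sits on a saturated chain carbon bound to an aromatic carbon and two saturated chain carbons in compound 2, and five bonds along the chain from an aromatic carbon in compound 4, so core and place change together.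

As far as these compounds go, whether a chain longer than hexyl would lower the number further remains open. So does how an amine or a carboxylic acid in place of the chain would read in this assay.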